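Chloro to cyano at the ring position of compound 3

A few compounds are considered here, and "the series" means these few. Any claim that something is new, unique, unknown or untested is made for them only; others in the source may bear on it.

Measured so far in a functional assay on MCF7 cells (Homo sapiens) for cytotoxicity, read by CellTiter-Glo, with a stated time of 5 days; a higher number here means a weaker inhibitor, a lower number a stronger inhibitor:
compound 1 `CC/C(=C(/c1ccc(/C=C/C(=O)O)cc1)c1ccc2[nH]ncc2c1)c1ccccc1` gives 7.2 nM;
compound 2 `CC/C(=C(/c1ccc(/C=C/C(=O)O)cc1)c1ccc2[nH]ncc2c1C)c1ccccc1` gives 50 nM;
compound 3 `CC/C(=C(/c1ccc(/C=C/C(=O)O)cc1)c1ccc2[nH]ncc2c1Cl)c1ccccc1` gives 1.6 nM.

Compound 3 has the lowest number of the three, sitting below compound 1 and well below compound 2 in this assay. The next compound, compound 4 `CC/C(=C(/c1ccc(/C=C/C(=O)O)cc1)c1ccc2[nH]ncc2c1C#N)c1ccccc1`, differs from compound 3 by cyano in place of chloro on an aromatic carbon.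

Within the data shown here, no measured step exchanges chloro for cyano, so the bearing steps are indirect. Replacing hydrogen at this position gave a 6.9-fold higher number from compound 1 to compound 2 (0.84 log units; beyond the scatter) for methyl and a 4.5-fold lower number from compound 1 to compound 3 (0.65 log units; beyond the scatter) for chloro, and the direct exchange gave a 31-fold lower number from compound 2 to compound 3 (1.49 log units; beyond the scatter). Two small groups at the same place thus pulled the number in opposite directions, so the outcome for cyano cannot be read from size alone. Compound 4 is expected to stay within the span of compounds 1 and 3, with a step of a 2.5-fold higher number from compound 3 to compound 4 (0.40 log units; beyond the scatter) expected. The estimate for compound 4 is 4 nM, ranging from 1 nM to 20 nM.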

Compound 4, half-maximal inhibitory concentration: 1.5 nM
Compound 4: middle estimate off by 2.7-fold (0.43 log units), on the high side; low and high end bracket the measured number.
By their numbers in this assay, from the lowest: compounds 4 and 3 (each within the scatter of the next); then compound 1; then compound 2.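

In this assay, chloro and cyano cannot be told apart at this position: a 1.1-fold lower number from compound 3 to compound 4 (0.03 log units; within the scatter), even though the entering group has one more heavy atom and a hydrogen-bond acceptor. Cyano in place of hydrogen gives a 4.8-fold lower number from compound 1 to compound 4 (0.68 log units; beyond the scatter), so among the three groups placed here on the core of compound 1, chloro and cyano both lower the number, and methyl is the exception, as a 33-fold lower number from compound 2 to compound 4 (1.52 log units; beyond the scatter) shows again. No measurement shown here bears on why methyl parts from the other two groups.

Still open, as far as these compounds go, is whether the lowering extends to other groups at this ring position, such as fluoro, methoxy or an amine. Also open, from the compounds shown here alone, is whether the match between chloro and cyano holds in any read-out other than this cell assay.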